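Shortening the ether chain of compound 3

The compounds below may be only part of what the source reports. "The series", "measured", "known", "first", "only" and "open" are said of these compounds alone.

Compound 3 `Cc1cc(Nc2nc(C(=O)NCCCOC(C)C)cs2)cc(C)c1Cl` carries an isopropoxy group at the end of its chain. In an ADME assay on MDCK cells (Canis lupus familiaris) for cytotoxicity, with a stated time of 48 h (a higher number here means that more compound is tolerated, a lower number that less compound is tolerated), compound 3 gives > 100000 nM, which is a limit of the assay rather than a number. Compound 1 `Cc1cc(Nc2nc(C(=O)NCCCOC(C)C)cs2)ccc1Cl` also sits at a limit: in this assay compound 1 gives > 100000 nM. Compound 2 `CCOCCCNC(=O)c1csc(Nc2ccc(Cl)c(C)c2)n1` gives 52000 nM in this assay. The step of an at least 1.9-fold lower number from compound 1 to compound 2 (0.28 log units; that floor lies within the scatter) shows what the change from isopropoxy to ethoxy did there. The step that the two limits leave unreadable from compound 1 to compound 3 cannot be read, as both of its values sit at the limit of > 100000 nM in this assay, at which 2 of the 3 values shown sit. Compound 4 `CCOCCCNC(=O)c1csc(Nc2cc(C)c(Cl)c(C)c2)n1` differs from compound 3 by hydrogen in place of methyl on a saturated chain carbon bound to an oxygen on a saturated carbon and a saturated chain carbon, the same change. Compound 4 is therefore expected near 60000 nM, within 25000 nM to 150000 nM. The expected step is an at least 1.6-fold lower number from compound 3 to compound 4 (0.22 log units; that floor lies within the scatter), downward but within the scatter.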

Compound 4, half-maximal cytotoxic concentration: > 100000 nM
Compound 4: only a limit was reported (the forecaster's own chance of this, stated with the estimate: 40%); middle value at least 1.6-fold (0.22 log units) from the limit.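

With the added methyl on an aromatic carbon in place, the change from isopropoxy to ethoxy no longer brings a measurable value: compound 4 stays at a limit of this assay. The step out of compound 2 is an at least 1.9-fold higher number from compound 2 to compound 4 (0.28 log units; that floor lies within the scatter), so that methyl cannot be said to matter. The steps between two limits cannot be read: the limit of > 100000 nM in this assay, at which 3 of the 4 values shown sit.

From the compounds shown here alone, how far compound 3 and compound 4 truly differ stays open. So does whether a longer chain or an amine at the chain end would bring a measurable value.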